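The source may hold more compounds than are shown below. What is called first, only, known or untested is meant among the compounds shown, and "the series" means these compounds.

Three close analogues were examined in an assay on isolated protein for binding affinity to 5-hydroxytryptamine receptor 1E (Homo sapiens); a lower number here means a stronger inhibitor, a higher number a weaker inhibitor. Compound 1 `Fc1cccc(-c2n[nH]cc2N2CCCNCC2)c1` carries a fluoro group on its aromatic ring, and in this assay compound 1 returns only a limit of the assay, > 10000 nM. Compound 2 `Fc1ccc(-c2n[nH]cc2N2CCCNCC2)cc1` is built from the same atoms joined differently; the difference between the two cores is not broken down here. In this assay compound 2 likewise returns only a limit, > 10000 nM. Compound 3 `COc1cccc(-c2n[nH]cc2N2CCCNCC2)c1` differs from compound 1 in a single place: methoxy in place of fluoro on an aromatic carbon. In this assay compound 3 too gives only a limit, > 10000 nM. Between the two there is therefore a step that the two limits leave unreadable from compound 1 to compound 3, and the reason this step cannot be sized is simply (the limit of > 10000 nM in this assay, at which 3 of the 3 values shown sit).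

Compound 4 `COc1ccc(-c2n[nH]cc2N2CCCNCC2)cc1` has not yet been measured. It differs from compound 2 by the same kind of change: methoxy in place of fluoro on an aromatic carbon. Around the place the two cases are not identical, since in compound 3 the methoxy sits meta to a large group, whereas in compound 4 it sits para to a large group. Since compound 1, compound 2 and compound 3 all sit at the limit of > 10000 nM in this assay, at which 3 of the 3 values shown sit, the step that the limit leaves unreadable from compound 2 to compound 4 is expected to be unreadable in the same way. Compound 4 is therefore estimated at 15000 nM, most probably again as a limit rather than a number.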

Compound 4, inhibition constant: > 10000 nM
Compound 4: no number, only a limit; the forecaster's own chance of this, stated with the estimate: 85%; the middle value is on the limit's open side.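

In this assay compound 4 also gives only a limit of the assay, > 10000 nM. No size can therefore be read for the change from compound 2 to compound 4: the limit of > 10000 nM in this assay, at which 4 of the 4 values shown sit.

The compounds shown leave open how strongly compound 1, compound 2, compound 3 and compound 4 bind, and whether methoxy and fluoro differ at all in this assay.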